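Nitro-trifluoromethyl thiazinone piperazines: cytotoxicity on Vero cells

The source may report more compounds than this note shows. Statements on the series, on what has been measured and on what is new or still open speak of the compounds shown alone.

Measured so far:
compound 1, `O=C(c1ccccc1F)N1CCN(c2nc(=O)c3cc(C(F)(F)F)cc([N+](=O)[O-])c3s2)CC1`, > 125000 nM
compound 2, `O=c1nc(N2CCN(CC3CCCCC3)CC2)sc2c([N+](=O)[O-])cc(C(F)(F)F)cc12`, > 125000 nM

In an ADME assay on Vero cells (Chlorocebus sabaeus) for cytotoxicity, read by MTT assay, with a stated time of 72 h (on this read-out higher numbers stand for lower toxicity in this test and lower numbers for higher toxicity in this test), compound 1 reaches only the upper limit of the test, > 125000 nM. In this assay compound 2 likewise gives only a limit, > 125000 nM. The step that the two limits leave unreadable from compound 1 to compound 2 therefore cannot be sized, since (the limit of > 125000 nM in this assay, at which 2 of the 2 values shown sit). Compound 3, `O=C(c1ccccc1Cl)N1CCN(c2nc(=O)c3cc(C(F)(F)F)cc([N+](=O)[O-])c3s2)CC1`, carries (2-chlorophenyl)carbonyl in place of cyclohexylmethyl on an amine nitrogen in a ring. Among the measured compounds shown here, no measured step reads on this change, so compound 3 is expected to sit near the same limit, an estimated step that the limit leaves unreadable from compound 2 to compound 3. Compound 3 is estimated at 150000 nM, within 60000 nM to 400000 nM.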

Compound 3, half-maximal cytotoxic concentration: > 125000 nM
Compound 3 was reported as a limit; the forecaster's own chance of this, stated with the estimate: 80%; the middle value does not contradict the limit.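

No new step can be read between compound 1, compound 2 and compound 3, because all three give only the same limit: the limit of > 125000 nM in this assay, at which 3 of the 3 values shown sit.

The compounds shown leave open whether any of these changes on the amine nitrogen or the aromatic carbon alters the read-out in this assay at all.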